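Selenium Substituents on a Shared Core Against Breast Cancer Cells

The source may report more compounds than this note shows. Statements on the series, on what has been measured and on what is new or still open speak of the compounds shown alone.

This small series shares one core and varies the group attached to a selenium. Compound 1 `COc1ccc(CNc2nc([SeH])nc3ccccc23)cc1` carries a hydrogen on its selenium. Compound 2 `C[Se]c1nc([Se]C)c2cccnc2n1` is a differently substituted relative; in a functional assay on MCF7 cells (Homo sapiens) for cytotoxicity, read by MTT assay, with a stated time of 72 h (a lower number here means a stronger inhibitor of growth, a higher number a weaker inhibitor of growth), compound 2 gives "not determined" (no result reported). Compound 3 `CCCCC[Se]c1nc(NCc2ccc(SC)cc2)c2ccccc2n1` carries a pentyl chain on its selenium. In this assay compound 3 gives 65000 nM, the lower of the two numbers recorded so far. In this assay compound 1 gives 94000 nM, a value that lies within the scatter of compound 3, so the two cannot be placed in order. Compound 4 `CSc1ccc(CNc2nc([SeH])nc3ccccc23)cc1` has not yet been measured. The change from compound 3 to compound 4 is hydrogen in place of pentyl on a selenium. Among the measured compounds shown here, no measured pair shows this change directly, so the expectation rests on resemblance. Compound 4 is expected to give 90000 nM, within a range from 45000 nM to 180000 nM, because compound 1 gives 94000 nM while also bearing a hydrogen on its selenium. The step of a 1.4-fold higher number from compound 3 to compound 4 (0.14 log units; within the scatter) is expected to stay within the scatter rather than beyond it.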

Compound 4, concentration for total growth inhibition: > 100000 nM
Compound 4 was reported as a limit; the forecaster's own chance of this, stated with the estimate: 10%; at least 1.1-fold (0.04 log units) between middle value and limit.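

Among the compounds shown here, for the first time, a measured pair shows hydrogen in place of pentyl on a selenium whose other neighbour is an aromatic carbon, and the step is an at least 1.5-fold higher number from compound 3 to compound 4 (0.18 log units; that floor lies within the scatter); its true size stays unknown. The second new pair shows methylsulfanyl in place of methoxy on an aromatic carbon, with an at least 1.0-fold higher number from compound 1 to compound 4 (0.02 log units; that floor lies within the scatter), so neither change can yet be said to alter growth inhibition. In this assay, compound 4 is reported as a limit and not as a number, which leaves both steps as floors: the limit of > 100000 nM in this assay, at which 1 of the 4 values shown sits.

The compounds shown leave open how an ethyl group or a longer chain such as octyl on the selenium would compare with pentyl. They also leave open whether a chain ending in an amine or a carboxylic acid would read differently in this assay.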